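The source may hold more compounds than are shown below. What is called first, only, known or untested is meant among the compounds shown, and "the series" means these compounds.

In a functional assay on A549 cells (Homo sapiens) for antiproliferative activity, read by MTT assay, with a stated time of 72 h (a higher number here means a weaker inhibitor, a lower number a stronger inhibitor), compound 1 `CC/C=C/C(=O)Nc1cccc(Oc2nc(Nc3ccn(C)n3)nc3c2CSCC3)c1` gives 36800 nM, compound 2 `CC(C)=CC(=O)Nc1cccc(Oc2nc(Nc3ccn(C)n3)nc3c2CSCC3)c1` gives 44200 nM and compound 3 `C=C(C)C(=O)Nc1cccc(Oc2nc(Nc3ccn(C)n3)nc3c2CSCC3)c1` gives 46900 nM. Compound 1 thus stands level with the other two: a 1.2-fold higher number from compound 1 to compound 2 (0.08 log units; within the scatter) and a 1.3-fold higher number from compound 1 to compound 3 (0.11 log units; within the scatter) are both within the scatter, as is a 1.1-fold higher number from compound 2 to compound 3 (0.03 log units; within the scatter). Compound 4 `CC/C=C/C(=O)Nc1cccc(Oc2nc(Nc3ccc(OC)nc3)nc3c2CSCC3)c1` keeps the but-1-en-1-yl on the carbonyl carbon and differs elsewhere: 6-methoxypyridin-3-yl in place of 1-methyl-1H-pyrazol-3-yl on a nitrogen on an aromatic ring. All three measured steps change the group on the carbonyl carbon, so none of them gives a size for this exchange on the nitrogen. No step beyond the scatter in this assay is expected, in either direction, though the uncertainty is wide. The estimated step is a 1.2-fold lower number from compound 1 to compound 4 (0.09 log units; within the scatter). For compound 4 the expected value is 30000 nM, with an estimated range of 10000 nM to 70000 nM.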

Compound 4, half-maximal inhibitory concentration: 13100 nM
The estimate for compound 4 lay 2.3-fold (0.36 log units) above the measured number, within the range that was stated.
By their numbers in this assay, from the lowest: compound 4; then compounds 1, 2 and 3 (each within the scatter of the next).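

In this assay the change from (1-methyl-1H-pyrazol-3-yl)amino to (6-methoxypyridin-3-yl)amino gives a 2.8-fold lower number from compound 1 to compound 4 (0.45 log units; beyond the scatter) and so moves the number beyond the scatter, which no change on the carbonyl carbon did among these compounds. The step is modest and rests on one pair, with but-1-en-1-yl held fixed. Nothing available explains this shift.

On these data alone, whether the same exchange gives a similar step with 2-methylprop-1-en-1-yl or 1-methylethenyl on the carbonyl carbon remains open. Also open, as far as these compounds go, is how a pyridin-3-yl without the methoxy group, or a 6-aminopyridin-3-yl, would read on that nitrogen.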